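From One Methoxy Group to Three on Compound 1

This account rests on a few compounds, and the source may have more. Where it says the series, first, only, none or still open, it means among the compounds named here.

For the measured compounds named here, compound 1 `CCCCCCCCCCCCCCCCCCNC(=O)[C@@H]1CSC(c2ccc(OC)cc2)N1` holds the lower of the two numbers measured so far in a functional assay on PPC-1 cells (Homo sapiens) for antiproliferative activity, read by sulforhodamine B assay (a lower number here means a stronger inhibitor, a higher number a weaker inhibitor), where compound 1 gives 1500 nM. Compound 2 `CCCCCCCCCCCCCCCCCCNC(=O)[C@@H]1CSC(c2ccc(OCC)cc2)N1` gives 4400 nM, and the step of a 2.9-fold higher number from compound 1 to compound 2 (0.47 log units; beyond the scatter) was modest. Compound 3 `CCCCCCCCCCCCCCCCCCNC(=O)[C@@H]1CSC(c2c(OC)cc(OC)cc2OC)N1` differs from compound 1 by 2,4,6-trimethoxyphenyl in place of 4-methoxyphenyl on a saturated ring carbon. Going by the values given here, no measured step adds methoxy groups to that ring, so the only guide is that the one change made to the same ring, a 2.9-fold higher number from compound 1 to compound 2 (0.47 log units; beyond the scatter), weakened the compound. Compound 3 is therefore expected at 3000 nM, within 800 nM to 12000 nM. The expected step is a 2.0-fold higher number from compound 1 to compound 3 (0.30 log units; within the scatter).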

Compound 3, half-maximal inhibitory concentration: 830 nM
Beside the measured number, compound 3's estimate is 3.6-fold (0.56 log units) above it; the range from low to high includes it.
By their numbers in this assay, from the lowest: compounds 3 and 1 (each within the scatter of the next); then compound 2.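

At this saturated ring carbon, 2,4,6-trimethoxyphenyl in place of 4-methoxyphenyl gives a 1.8-fold lower number from compound 1 to compound 3 (0.26 log units; within the scatter) in this assay, so the added methoxy groups are tolerated. Against 4-ethoxyphenyl, the same group gives a 5.3-fold lower number from compound 2 to compound 3 (0.72 log units; beyond the scatter), so the loss seen with the ethoxy group does not follow from a larger group on this ring carbon alone. Nothing available explains these differences.

Which of the three methoxy groups matter remains open. So does whether a hydroxyl or an amine on this aromatic ring would keep the compound in the same range.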